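The source may report more compounds than this note shows. Statements on the series, on what has been measured and on what is new or still open speak of the compounds shown alone.

Values in a functional assay on HCT-116 cells (Homo sapiens) for inhibition, read by CCK-8 assay, with a stated time of 48 h (on this read-out lower numbers stand for stronger inhibition and higher numbers for weaker inhibition), so far:
- compound 1 `COc1ccc(CN(C(=O)CSC(=S)N2CCN(C(C)=O)CC2)c2cc(OC)c(OC)c(OC)c2)cc1` gives 1370 nM 
- compound 2 `COc1ccc(CN(C(=O)CSC(=S)N2CCN(C)CC2)c2cc(OC)c(OC)c(OC)c2)cc1O` gives 810 nM 

Compound 2 at 810 nM lies within the scatter of compound 1, so the two values set no order. Among the measured compounds shown here, compound 3 `COc1ccc(CN(C(=O)CSC(=S)N2CCN(C(C)=O)CC2)c2cc(OC)c(OC)c(OC)c2)cc1O` carries acetyl in place of methyl on an amine nitrogen in a ring, the counted change being acetyl in place of methyl on an amine nitrogen in a ring and no measured pair shows this change alone. Compound 1 at 1370 nM also carries the 4-acetylpiperazin-1-yl group, so no step beyond the scatter is expected in this assay here. The estimated 1.4-fold higher number from compound 2 to compound 3 (0.13 log units; within the scatter) is small and points toward a higher number. For compound 3 the expected value is 1100 nM with an estimated range from 450 nM to 2700 nM in this measurement.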

Compound 3, half-maximal inhibitory concentration: 780 nM
Estimate against measurement, compound 3: 1.4-fold (0.15 log units) above; the measured number falls inside the stated range.
By their numbers in this assay, from the lowest: compounds 3, 2 and 1 (each within the scatter of the next).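

In this assay acetyl in place of methyl on the ring amine nitrogen gives a 1.0-fold lower number from compound 2 to compound 3 (0.02 log units; within the scatter) and so leaves the number unmoved at this position, with 4-acetylpiperazin-1-yl and 4-methylpiperazin-1-yl not told apart. With the acetyl group held constant, hydroxy in place of hydrogen on an aromatic carbon gives a 1.8-fold lower number from compound 1 to compound 3 (0.24 log units; within the scatter) and also separates nothing. No measurement on hand accounts for either step.

Open, from the compounds shown here alone, is whether a carboxylic acid chain or a longer acyl chain on that nitrogen would give a step beyond the scatter.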